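From an Amide to a Carbamate on a Shared Core

The source may hold more compounds than are shown below. What is called first, only, known or untested is meant among the compounds shown, and "the series" means these compounds.

For the measured compounds named here, in a functional assay on WI-38 VA13 cells (Homo sapiens) for cytotoxicity (a higher number here means that more compound is needed for the effect, a lower number that less compound is needed), compound 2 `CCCC(=O)Nc1nc2ccc(NC(=O)c3c(Cl)cccc3Cl)cc2s1` gives 0.01 ug/mL, the lowest of the two numbers measured so far. Compound 1 `O=C(Nc1ccc2nc(NC(=O)C3CCCCC3)sc2c1)c1cccc(F)c1` gives 0.64 ug/mL in this assay, a far higher number, well beyond the usual scatter. Compound 3 `CC(C)COC(=O)Nc1nc2ccc(NC(=O)c3c(Cl)cccc3Cl)cc2s1` differs from compound 2 in a single place: isobutoxy in place of propyl on a carbonyl carbon. Going by the values given here, no measured pair shows what this change does, so the expectation rests on compound 2 alone, with a modest rise in the number judged more likely than a fall: the estimated step of a 3.0-fold higher number from compound 2 to compound 3 (0.48 log units; beyond the scatter) is small. Compound 3 is accordingly expected to give about 0.03 ug/mL in this assay, with a range from 0.005 ug/mL to 0.2 ug/mL.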

Compound 3, half-maximal effective concentration: 0.0035 ug/mL
Compound 3: middle estimate off by 8.6-fold (0.93 log units), on the high side, and the stated range ends above it.
By their numbers in this assay, from the lowest: compound 3; then compound 2; then compound 1.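

In this assay, isobutoxy in place of propyl on the carbonyl carbon gives a 2.9-fold lower number from compound 2 to compound 3 (0.46 log units; beyond the scatter). This turns the amide of compound 2 into the carbamate of compound 3, and the position accepts the larger group, with its added oxygen, without any rise in the number. No available measurement explains this modest fall.

This single pair cannot separate the effect of the oxygen from that of the longer, branched chain, which a butyl group on the same carbon could help to resolve. From the compounds shown here alone, how a smaller methoxy group or an amine would behave at this position also remains open.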